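The source may report more compounds than this note shows. Statements on the series, on what has been measured and on what is new or still open speak of the compounds shown alone.

Compound 1 `C[C@H](NC(=O)[C@@]1(Cc2ccccc2)CCN1C(=O)OCc1ccccc1)C(=O)NC(C)(C)C`: > 100000 nM
Compound 2 `CC(C)[C@H](NC(=O)[C@@]1(Cc2ccccc2)CCN1C(=O)OCc1ccccc1)C(N)=O`: > 100000 nM

In an ADME assay on HELF cells (Homo sapiens) for cytotoxicity, with a stated time of 3 days (a lower number here means that less compound is tolerated, a higher number that more compound is tolerated), compound 1 gives > 100000 nM, which is a limit of the assay and not a number. In this assay compound 2 likewise gives > 100000 nM, again a limit rather than a number. For the measured compounds named here, compound 2 therefore stands at the top of what the assay can report, and it cannot be ordered against compound 1; the only step between measured compounds, a step that the two limits leave unreadable from compound 1 to compound 2, has no readable size, because of the limit of > 100000 nM in this assay, at which 2 of the 2 values shown sit.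

Compound 3 `C[C@H](NC(=O)[C@@]1(Cc2ccccc2)CCN1C(=O)OCc1ccccc1)C(=O)NCc1ccccc1` has not yet been measured. Its change from compound 2 is 1-(benzylcarbamoyl)ethyl in place of 1-carbamoyl-2-methylpropyl on an amide-type nitrogen. Going by the values given here, the single measured step bears on it only in that both of its ends sit at the limit, so no size or direction of step can be drawn from it. Compound 3 is accordingly expected to remain at the same limit, with an estimated step of a number no higher from compound 2 to compound 3 (the limit leaves the size open) in this assay that does not rise beyond the scatter. For compound 3 the estimate in this assay is 100000 nM, within a range of 30000 nM to 300000 nM.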

Compound 3, minimum cytotoxic concentration: >= 20000 nM
Compound 3 gave a limit, no number; the forecaster's own chance of this, stated with the estimate: 80%; the middle value is on the limit's open side.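

In this assay compound 3 gives >= 20000 nM, which is a limit of the assay and not a number. Its steps from compound 1 and from compound 2 cannot be read, as both pairs end in limits. The compounds shown leave open the minimum cytotoxic concentration of compound 1, compound 2 and compound 3, and whether benzyl in place of tert-butyl changes it.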